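Methyl for methoxy on the chalcone: an expected step

This account rests on a few compounds, and the source may have more. Where it says the series, first, only, none or still open, it means among the compounds named here.

Measured compounds:
compound 1 `O=C(/C=C/c1ccccc1[N+](=O)[O-])c1ccc(O)cc1O`: 20.2%
compound 2 `COc1ccc(/C=C/C(=O)c2ccc(O)cc2O)cc1`: 51.4%

Of the compounds shown here, two have been measured in a functional assay on the whole organism (Ear, strain Kunming) for inhibition, with Mus musculus as the target, with a stated time of 2 h, at a dose of 200 mg/kg by the oral route; a lower number here means less inhibition, a higher number more inhibition at the dose given (going by the name of the read-out). Compound 1 `O=C(/C=C/c1ccccc1[N+](=O)[O-])c1ccc(O)cc1O` gives 20.2% in this assay, while compound 2 `COc1ccc(/C=C/C(=O)c2ccc(O)cc2O)cc1` gives 51.4%. Compound 2 thus stands highest of the two numbers, and its nearest neighbour, compound 1, lies lower by a gap beyond the scatter. Among the measured compounds shown here, no step between compounds differing in a single place has been measured, so the size of such steps on this core is not yet known.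

Compound 3 `Cc1ccc(/C=C/C(=O)c2ccc(O)cc2O)cc1` differs from compound 2 in one place: methyl in place of methoxy on an aromatic carbon. From compound 2 to compound 3 a small downward step, or none beyond the scatter, is expected, so that the step is estimated at a number 6.4 percentage points lower from compound 2 to compound 3 (within the scatter) in this assay. For compound 3 an inhibition of 45% is therefore expected in this assay, with a range from 28% to 62%.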

Compound 3, a percentage reported as inhibition, in the whole organism at one dose (the size of the read-out at that dose, not a potency): "not active" (no number reported)
No number was reported for compound 3; no gap can be computed for the estimate.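

Among the compounds shown here, compound 3 was reported as "not active" with no number, so no step from compound 2 to compound 3 can be read. The compounds shown leave open how large the change from methoxy to methyl is on this shared core. No evidence shown bears on this result.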